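The source may hold more compounds than are shown below. What is called first, only, known or untested is meant among the compounds shown, and "the series" means these compounds.

Measured so far in a physicochemical assay for acid dissociation:
compound 1 `c1ccc(Oc2ccc3c(NCCCNCc4ccco4)ccnc3c2)cc1`, 9.28
compound 2 `Fc1ccc(-c2ccc3c(NCCCNCc4ccco4)ccnc3c2)cc1`, 9.47
compound 3 `COc1ccc(F)cc1CNCCCNc1ccnc2cc(-c3cccc4ccccc34)ccc12`, 9.47

Compound 3 shares its value with compound 2, and these two are the highest of the three; compound 1 sits lower, but only within the scatter.

Compound 4 `c1coc(CNCCCNc2ccnc3cc(-c4cccc5ccccc45)ccc23)c1` differs from compound 3 in one place: furan-2-yl in place of 5-fluoro-2-methoxyphenyl on a saturated chain carbon bound to an amine nitrogen. Among the compounds with values here, no measured step changes this group. Within the data shown here, the only measured step, a number 0.19 log units higher from compound 1 to compound 2 (within the scatter), concerns the aryl on the shared core and stayed within the scatter. Compound 2 already carries the (furan-2-yl)methyl group and gives the same value as compound 3, so the group on the amine side appears not to move the number here.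

In this assay compound 4 is therefore expected to show a number 0.05 log units lower from compound 3 to compound 4 (within the scatter), nothing beyond the scatter. The estimate for compound 4 is 9.42, with a range of 9.12 to 9.72.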

Compound 4, acid dissociation constant: 9.47
Estimate against measurement, compound 4: 0.05 log units below; the range from low to high includes it.
By their numbers in this assay, from the lowest: compounds 1, 2, 3 and 4 (each within the scatter of the next).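

In this assay, the group on the saturated chain carbon bound to an amine nitrogen now has a measured step: furan-2-yl in place of 5-fluoro-2-methoxyphenyl gives no change at the digits printed from compound 3 to compound 4 (within the scatter), so this change is not resolved here. On the aromatic carbon, naphthalen-1-yl in place of 4-fluorophenyl gives no change at the digits printed from compound 2 to compound 4 (within the scatter), and in place of phenoxy gives a number 0.19 log units higher from compound 1 to compound 4 (within the scatter), so neither change is resolved either. No evidence bears on this result.

Going by these compounds, whether a carboxylic acid at the chain carbon, or a longer chain, would give a step beyond the scatter remains open.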